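Swapping cyano for methyl: what compound 3 may show

The source may hold more compounds than are shown below. What is called first, only, known or untested is meant among the compounds shown, and "the series" means these compounds.

Measured in an ADME assay (liver) for metabolic stability, with Liver microsome (Homo sapiens) as the target, read by LC-MS, using microsomes, with a stated time of 30 min, tested at 4 uM; on this read-out lower numbers stand for a less stable compound and higher numbers for a more stable compound:
- compound 1 `Cc1nc(N2CCN(C)CC2)c2nc(-c3cccc(Cl)c3)n(C3CCOCC3)c2n1`: 25%
- compound 2 `Cc1nc(N2CCN(C)CC2)c2nc(-c3ccccc3C#N)n(C3CCOCC3)c2n1`: 20%

Within the data shown here, at 20%, compound 2 stands within the scatter of compound 1, the only other compound measured. The next compound, compound 3 `Cc1nc(N2CCN(C)CC2)c2nc(-c3ccccc3C)n(C3CCOCC3)c2n1`, keeps the shared core and carries methyl in place of cyano on an aromatic carbon, ortho to a large group: methyl in place of cyano on an aromatic carbon.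

Among the measured compounds shown here, only one measured step bears on this change: a number 5 percentage points lower from compound 1 to compound 2 (within the scatter). For the measured compounds named here, that step also involves the 2-cyanophenyl group, but no measurement yet compares cyano with methyl directly. The data therefore point in no direction, and no step beyond the scatter is expected in this assay. The expected step is no change at the digits printed from compound 2 to compound 3 (within the scatter). Compound 3 is estimated at 20%, with an expected range from 7% to 38%.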

Compound 3, percent of the compound remaining: 18%
The estimate for compound 3 lay 2 percentage points above the measured number, and the stated range covers the measured number.
By their numbers in this assay, from the lowest: compounds 3, 2 and 1 (each within the scatter of the next).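

In this assay, among these compounds, the first direct comparison of methyl with cyano on this aromatic carbon, ortho to a large group, gives a number 2 percentage points lower from compound 2 to compound 3 (within the scatter), so the read-out does not separate the two groups at this place. The change from 3-chlorophenyl to 2-methylphenyl gives a number 7 percentage points lower from compound 1 to compound 3 (within the scatter), so this exchange also leaves the number inside the scatter, and no change shown so far has moved it beyond that. Nothing measured here offers an explanation for this result.

Still open, on these data alone, is whether a different kind of group at this place, such as an amine, a carboxylic acid or a longer chain, would give a step beyond the scatter in this assay. The compounds shown also leave open how changes elsewhere on the shared core would read in this assay.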